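Swapping the Aryl Group on a Shared Core

A few compounds are considered here, and "the series" means these few. Any claim that something is new, unique, unknown or untested is made for them only; others in the source may bear on it.

In a functional assay on A549 cells (Homo sapiens) for antiproliferative activity, read by MTT assay, with a stated time of 72 h (on this read-out higher numbers stand for weaker inhibition and lower numbers for stronger inhibition), compound 1 `CCOc1ccc(-c2ccc3ncn(-c4cc(OC)c(OC)c(OC)c4)c3c2)cc1` gives 8550 nM. Compound 2 `COc1cc(-n2cnc3ccc(-c4ccc(C)cc4F)cc32)cc(OC)c1OC` gives > 10000 nM, which is a limit of the assay and not a number. The next compound, compound 3 `COc1ccc(-c2ccc3ncn(-c4cc(OC)c(OC)c(OC)c4)c3c2)cc1O`, has not yet been measured. It carries 3-hydroxy-4-methoxyphenyl in place of 2-fluoro-4-methylphenyl on an aromatic carbon. For the measured compounds named here, only one measured step bears on this, an at least 1.1-fold higher number from compound 1 to compound 2 (0.06 log units; that floor lies within the scatter), so it says little about size. Compound 3 keeps an oxygen-linked chain on this ring, as compound 1 does at 8550 nM, so a lower number is expected, with much uncertainty. The expected step in this assay is an at least 12-fold lower number from compound 2 to compound 3 (1.09 log units; beyond the scatter), towards stronger inhibition. Compound 3 is estimated at 800 nM, with an expected range of 60 nM to 9000 nM.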

Compound 3, half-maximal inhibitory concentration: 200 nM
Estimate against measurement, compound 3: 4.0-fold (0.60 log units) above; the range from low to high includes it.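

In this assay, placing 3-hydroxy-4-methoxyphenyl on this aromatic carbon instead of 4-ethoxyphenyl gives a 43-fold lower number from compound 1 to compound 3 (1.63 log units; beyond the scatter), so changing the aryl group here can shift activity strongly, which compound 1 and compound 2 alone could not show. Replacing 2-fluoro-4-methylphenyl with the same group gives an at least 50-fold lower number from compound 2 to compound 3 (1.69 log units; beyond the scatter). That step is only a floor, since compound 2 stands at a limit of the assay and not a number: the limit of > 10000 nM in this assay, at which 1 of the 3 values shown sits.

The compounds shown do not separate the hydroxy group from the methoxy group, so it remains open which part of 3-hydroxy-4-methoxyphenyl goes with the lower number. On these data alone, it is also open whether an amine in place of that hydroxy group, or a longer chain in place of that methoxy group, would keep the activity.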